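Amide-side variation on the shared core: notes toward compound 4

This account rests on a few compounds, and the source may have more. Where it says the series, first, only, none or still open, it means among the compounds named here.

Measured so far in an ADME assay on HS27 cells (Homo sapiens) for antiproliferative activity, read by MTT assay, with a stated time of 24 h; a lower number here means a stronger inhibitor, a higher number a weaker inhibitor:
compound 1 `O=C(Nc1ccc(-n2ccc3c(NC(=O)c4ccccc4)ncnc32)cc1)c1ccc(Cl)c(Cl)c1` gives 5000 nM
compound 2 `O=C(Nc1ccc(-n2ccc3c(NC(=O)c4ccccc4)ncnc32)cc1)c1cc(C(F)(F)F)cc(C(F)(F)F)c1` gives 6600 nM
compound 3 `O=C(Nc1ccc(-n2ccc3c(NC(=O)c4ccccc4)ncnc32)cc1)c1cccc(C(F)(F)F)c1` gives 5900 nM

Compound 3 stands second highest of the three numbers; its nearest neighbour is compound 2 and its furthest compound 1, and both gaps lie within the scatter. Compound 4 `Cc1cn(-c2cc(C(=O)Nc3ccc(-n4ccc5c(NC(=O)c6ccccc6)ncnc54)cc3)cc(C(F)(F)F)c2)cn1` differs from compound 3 by 4-methyl-1H-imidazol-1-yl in place of hydrogen on an aromatic carbon. Going by the values given here, the two steps that touch this part of the molecule, a 1.2-fold higher number from compound 1 to compound 3 (0.07 log units; within the scatter) and a 1.1-fold lower number from compound 2 to compound 3 (0.05 log units; within the scatter), were both within the scatter, and neither adds a ring, so no measured step speaks directly for the new group. The expectation for compound 4 in this assay is therefore no step beyond the scatter, a 1.0-fold higher number from compound 3 to compound 4 (0.01 log units; within the scatter). Compound 4 is estimated at 6000 nM, between 2000 nM and 18000 nM.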

Compound 4, half-maximal inhibitory concentration: 2800 nM
The estimate for compound 4 lay 2.1-fold (0.33 log units) above the measured number; low and high end bracket the measured number.
By their numbers in this assay, from the lowest: compounds 4, 1, 3 and 2 (each within the scatter of the next, the first and the last beyond it).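

In this assay, going by these compounds alone, 4-methyl-1H-imidazol-1-yl on this aromatic carbon gives the first steps beyond the scatter: a 2.1-fold lower number from compound 3 to compound 4 (0.32 log units; beyond the scatter) with the group in place of hydrogen, and a 2.4-fold lower number from compound 2 to compound 4 (0.37 log units; beyond the scatter) with it in place of trifluoromethyl. The earlier changes on this ring added no new ring and stayed within the scatter, so this position can register a modest shift. No data shown account for that shift.

Still open, going by these compounds, is whether an unmethylated imidazole, an amine or a carboxylic acid on this carbon would give a step of similar size. Also open, on these data alone, is whether the step depends on the remaining trifluoromethyl group.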